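The compounds below may be only part of what the source reports. "The series", "measured", "known", "first", "only" and "open" are said of these compounds alone.

In a functional assay on K562 cells (Homo sapiens), read by MTT assay, with a stated time of 72 h (a lower number here means a stronger inhibitor, a higher number a weaker inhibitor), two compounds on a shared core have been measured so far. Compound 1 `CSc1ncnc2c1c(-c1ccsc1)cn2[C@@H]1O[C@H](CO)[C@@H](O)[C@H]1O` gives 450 nM and compound 2 `Cc1ncnc2c1c(-c1ccsc1)cn2[C@@H]1O[C@H](CO)[C@@H](O)[C@H]1O` gives 320 nM in this pair, so compound 2 stands level with compound 1 within the usual scatter. The next molecule is compound 3 `Cc1ncnc2c1c(I)cn2[C@@H]1O[C@H](CO)[C@@H](O)[C@H]1O` which keeps the methyl of compound 2 and changes another group. The change is iodo in place of thiophen-3-yl on an aromatic carbon and it sits on an aromatic carbon of a five-membered aromatic ring with 1 nitrogen. For the measured compounds named here, the only measured step of a 1.4-fold lower number from compound 1 to compound 2 (0.15 log units; within the scatter) swaps methylsulfanyl for methyl at a different place and gives no direct guide to this swap. Going by the values given here, with no measured example of losing the thiophen-3-yl, the estimated move is a 2.8-fold higher number from compound 2 to compound 3 (0.45 log units; beyond the scatter) in this assay as a modest rise in the number with wide uncertainty. For compound 3 the expected value is 900 nM within an estimated range from 150 nM to 6000 nM for repeated measurements.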

Compound 3, half-maximal inhibitory concentration: 17800 nM
Estimate against measurement, compound 3: 20-fold (1.30 log units) below; measured number above the stated range.
By their numbers in this assay, from the lowest: compounds 2 and 1 (each within the scatter of the next); then compound 3.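

In this assay, for the compounds shown here, iodo in place of thiophen-3-yl gives a 56-fold higher number from compound 2 to compound 3 (1.75 log units; beyond the scatter), whereas the only earlier step, made at a different place, stayed within the scatter. This shows that the group on this aromatic carbon of the five-membered aromatic ring with 1 nitrogen can strongly change the number: with the rest of compound 2 kept, swapping the thiophen-3-yl ring and its 5 heavy atoms for a single iodine leaves a much weaker inhibitor. No available evidence bears on the reason for this large rise.

The compounds shown leave open whether the thiophen-3-yl ring itself matters, or whether other groups on this carbon could do as well. A phenyl ring, a furan-3-yl ring, a plain hydrogen or a small amine here would help separate these possibilities.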